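Removing the Methylamino Group from a Weak Inhibitor

The source may report more compounds than this note shows. Statements on the series, on what has been measured and on what is new or still open speak of the compounds shown alone.

The measured compounds, with their values in a functional assay on KB cells (Homo sapiens) for inhibition; on this read-out lower numbers stand for stronger inhibition and higher numbers for weaker inhibition:
Compound 1 `CNc1c(C#N)c2c(N)ncnc2n1COCCOC` gives > 100000 nM, a limit of the assay.
Compound 2 `NC(=S)c1c(N)n(COCc2ccccc2)c2ncnc(N)c12` gives 225000 nM.
Compound 3 `NC(=O)c1c(N)n(COCc2ccccc2)c2ncnc(N)c12` gives > 100000 nM, a limit of the assay.

Compound 1 stands at the limit of this assay, and so no number is known for it; (the limit of > 100000 nM in this assay, at which 2 of the 3 values shown sit). Among the compounds with values here, the one value that is a number, that of compound 2, is weak. Within the data shown here, the only measured step, a step that the limit leaves unreadable from compound 2 to compound 3, exchanges one group for another on the shared core and cannot be read because of the limit.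

Compound 4 `COCCOCn1cc(C#N)c2c(N)ncnc21` differs from compound 1 in hydrogen in place of methylamino on an aromatic carbon. Among the measured compounds shown here, no measured step touches the methylamino group, so nothing among the measured compounds tells how its removal changes inhibition. All three measured compounds sit at or beyond the limit or close to it, and the change from compound 1 to compound 4 is expected to give a step, a step that the limit leaves unreadable from compound 1 to compound 4, that cannot be read either. Compound 4 is therefore estimated at 150000 nM, with a range from 50000 nM to 500000 nM, and most likely the assay will again report only a limit for compound 4.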

Compound 4, half-maximal inhibitory concentration: > 100000 nM
Compound 4: a limit, no number; the forecaster's own chance of this, stated with the estimate: 80%; the middle value lies beyond the limit too.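

In this assay compound 4 gives > 100000 nM as a limit of the assay and not a number. Compound 1 also stands at a limit, so no step can be read from compound 1 to compound 4: the limit of > 100000 nM in this assay, at which 3 of the 4 values shown sit.
The compounds shown leave open whether hydrogen in place of methylamino changes inhibition at all, and in which direction.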